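Replacing the oxetane ether with a pentamethylpiperidine

This account rests on a few compounds, and the source may have more. Where it says the series, first, only, none or still open, it means among the compounds named here.

Measured compounds:
compound 1, `NCCNC(=O)c1cc(-c2ccc(NS(=O)(=O)c3cccc(Cl)c3Cl)cc2)nc2[nH]ncc12` — < 1 nM
compound 2, `Cc1n[nH]c2nc(-c3ccc(NS(=O)(=O)c4cc(Cl)ccc4F)cc3)nc(OCC3(CN)COC3)c12` — 1 nM

Among the measured compounds shown here, in an assay for inhibition of serine/threonine-protein kinase Sgk1 (Homo sapiens), with stated times of 30 min and 60 min, in the presence of a further agent that is not named here (on this read-out higher numbers stand for weaker inhibition and lower numbers for stronger inhibition), compound 2 gives 1 nM, the only outright number among the two values shown. In this assay compound 1 gives < 1 nM; this is the limit of < 1 nM in this assay, at which 1 of the 2 values shown sits, so it stands as a limit and not as a number. Compound 2 therefore stands as the single fixed point from which the next compound is judged.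

Compound 3, `Cc1n[nH]c2nc(-c3ccc(NS(=O)(=O)c4cc(Cl)ccc4F)cc3)nc(OC3CC(C)(C)N(C)C(C)(C)C3)c12`, differs from compound 2 by 1,2,2,6,6-pentamethylpiperidin-4-yl in place of (3-(aminomethyl)oxetan-3-yl)methyl on an oxygen on an aromatic ring. For the measured compounds named here, no measured pair shows this change, so its effect in this assay is unknown. The step from compound 2 to compound 3 is expected to be a 2.0-fold higher number from compound 2 to compound 3 (0.30 log units; within the scatter), a small move toward weaker inhibition that may not exceed the usual scatter. On that basis compound 3 is estimated to give 2 nM in this assay, with a range from 0.5 nM to 10 nM.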

Compound 3, half-maximal inhibitory concentration: 3 nM
Beside the measured number, compound 3's estimate is 1.5-fold (0.18 log units) below it; measured number inside the range.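

In this assay, putting 1,2,2,6,6-pentamethylpiperidin-4-yl in place of (3-(aminomethyl)oxetan-3-yl)methyl on the oxygen gives a 3.0-fold higher number from compound 2 to compound 3 (0.48 log units; beyond the scatter). Among the compounds shown here, this is the first reading of a change at this position: a four-membered ring carrying a hydrogen-bond donor gives way to a larger six-membered ring with none, and compound 3 still gives 3 nM. Nothing measured here accounts for the size of this step.

The compounds shown leave open whether the ring size, the methyl groups or the missing hydrogen-bond donor sets the step, as all of these change together. They give no reading for an unmethylated piperidin-4-yl or a simple aminoethyl chain on the same oxygen, either of which would help to separate these features.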